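The source may report more compounds than this note shows. Statements on the series, on what has been measured and on what is new or still open speak of the compounds shown alone.

Series notes. In an assay on CHO cells for displacement of a labelled ligand from adenosine receptor A3 (Homo sapiens), read by scintillation counting, with a stated time of 60 min, tested at 1 uM (on this read-out higher numbers stand for more inhibition at the one concentration tested (going by the name of the read-out) and lower numbers for less inhibition), compound 1 `Cc1nc(NC(=O)NCc2ccccc2)c2nn(-c3ccccc3)cc2n1` gives 1%, compound 2 `COc1ccc(-n2cc3nc(C)nc(NC(=O)Nc4ccccc4)c3n2)cc1` gives 1%, and compound 3 `COc1ccc(-n2cc3nc(Cc4ccccc4)nc(N)c3n2)cc1` gives 45%. Compound 2 is level with compound 1 at the digits shown, the two together the lowest of the three numbers, while compound 3 stands higher by a margin beyond the scatter. Compound 4 `Cc1nc(NC(=O)Nc2ccccc2)c2nn(-c3ccccc3)cc2n1` is not yet measured. It differs from compound 2 by hydrogen in place of methoxy on an aromatic carbon. Within the data shown here, no measured pair shows this change on its own; the only guide is that compound 1, which carries the same phenyl, sits at 1%. For compound 4 the expected step is a number 2 percentage points higher from compound 2 to compound 4 (within the scatter), nothing beyond the scatter. Compound 4 is estimated at 3%, with a range from 0% to 15%.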

Compound 4, a percentage reported as inhibition, at one concentration (the size of the read-out at that concentration, not a potency): 30%
For compound 4 the middle estimate is 27 percentage points below the measured one; measured number above the stated range.
By their numbers in this assay, from the lowest: compounds 1 and 2 (each within the scatter of the next); then compound 4; then compound 3.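

In this assay, hydrogen in place of methoxy gives a number 29 percentage points higher from compound 2 to compound 4 (beyond the scatter), so this position on the aromatic ring is sensitive to the change from 4-methoxyphenyl to phenyl. Phenyl in place of benzyl on the amide-type nitrogen gives a number 29 percentage points higher from compound 1 to compound 4 (beyond the scatter), so that site is sensitive too. Within these pairs, the higher number needs both hydrogen on the ring and phenyl on the nitrogen.

As far as these compounds go, whether a fluorine or an amine at that ring position would keep the gain remains open. No supporting evidence bears on why either change acts.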